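The source may report more compounds than this note shows. Statements on the series, on what has been measured and on what is new or still open speak of the compounds shown alone.

Measured so far:
compound 1 `COc1ccc(C(=O)/C=C/c2ccc(F)cc2)c2c1C=CC(C)(C)O2` — > 10000 nM
compound 2 `COc1ccc(C(=O)/C=C/c2cccc3ccccc23)c2c1C=CC(C)(C)O2` — > 10000 nM

In a functional assay on HT-29 cells (Homo sapiens) for antiproliferative activity, read by MTT assay, with a stated time of 24 h (a lower number here means a stronger inhibitor, a higher number a weaker inhibitor), compound 1 gives > 10000 nM, which is a limit of the assay rather than a number. Compound 2 likewise gives only a limit, > 10000 nM. Compound 1 therefore stands at the edge of what this assay reports, and nothing separates it from compound 2 on the numbers shown; no step between measured compounds can be computed, since every value so far sits at the limit of > 10000 nM in this assay, at which 2 of the 2 values shown sit.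

Compound 3 `COc1ccc(C(=O)/C=C/c2ccc(Cl)c(Cl)c2)c2c1C=CC(C)(C)O2` differs from compound 1 by 3,4-dichlorophenyl in place of 4-fluorophenyl on a double-bonded chain carbon bound to a double-bonded chain carbon. With both measured values at the limit, no step size in this assay can be read from the data, and none beyond the scatter is expected in either direction. Compound 3 is expected to remain at the limit as well, because of the limit of > 10000 nM in this assay, at which 2 of the 2 values shown sit. The estimated step that the limit leaves unreadable from compound 1 to compound 3 is accordingly expected to be close to none. The estimate for compound 3 is 15000 nM, within 4000 nM to 60000 nM.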

Compound 3, half-maximal inhibitory concentration: 7580 nM
For compound 3 the middle estimate is 2.0-fold (0.30 log units) above the measured one; low and high end bracket the measured number.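

In this assay, this position gives a first readable result: with 3,4-dichlorophenyl in place of 4-fluorophenyl on a double-bonded chain carbon bound to a double-bonded chain carbon, compound 3 has a measured number, 7580 nM, and the change gives an at least 1.3-fold lower number from compound 1 to compound 3 (0.12 log units; that floor lies within the scatter). For compound 1 the value remains a limit of the assay, > 10000 nM. The true size of the step therefore cannot be read, and its floor alone does not establish a real difference, because the comparison starts from a limit: the limit of > 10000 nM in this assay, at which 2 of the 3 values shown sit.

From the compounds shown here alone, it remains open whether 4-chlorophenyl at this place would give a measurable number, which would help show whether both chlorines are needed. Also open, going by these compounds, is whether a different kind of substituent on the phenyl ring, such as an amine or a carboxylic acid, would move the number clearly away from the limit.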